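The source may report more compounds than this note shows. Statements on the series, on what has been measured and on what is new or still open speak of the compounds shown alone.

In a functional assay on HCT-116 cells (Homo sapiens) for antiproliferative activity, read by MTT assay, with a stated time of 48 h (on this read-out lower numbers stand for stronger inhibition of growth and higher numbers for weaker inhibition of growth), compound 1 `S=C(Nc1ccccc1)N1N=C(c2ccccc2)CC1c1ccc2c(c1)OCCO2` gives 57600 nM, while compound 2 `S=C(Nc1ccccc1)N1N=C(c2cccc(Cl)c2)CC1c1ccc2c(c1)OCCO2` gives 138000 nM, the highest of the two numbers. The step of a 2.4-fold higher number from compound 1 to compound 2 (0.38 log units; beyond the scatter) came with chloro in place of hydrogen on an aromatic carbon. Compound 3 `COc1cccc(C2=NN(C(=S)Nc3ccccc3)C(c3ccc4c(c3)OCCO4)C2)c1` differs from compound 2 by methoxy in place of chloro on an aromatic carbon. Within the data shown here, no measured step exchanges chloro for methoxy; only the step of a 2.4-fold higher number from compound 1 to compound 2 (0.38 log units; beyond the scatter) bears on this aromatic carbon, and it was modest. Compound 3 is therefore expected to show a modest downward step, a 1.5-fold lower number from compound 2 to compound 3 (0.19 log units; within the scatter). The estimate for compound 3 is 90000 nM, within 35000 nM to 250000 nM.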

Compound 3, concentration for 50% growth inhibition: > 200000 nM
Compound 3 gave a limit, no number (the forecaster's own chance of this, stated with the estimate: 15%); middle value at least 2.2-fold (0.34 log units) away from the limit.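

In this assay compound 3 reads > 200000 nM, which is a limit of the assay and not a number. Methoxy in place of hydrogen on this aromatic carbon moves the number the same way chloro did: an at least 3.4-fold higher number from compound 1 to compound 3 (0.54 log units; beyond the scatter). The change from 3-chlorophenyl to 3-methoxyphenyl gives an at least 1.4-fold higher number from compound 2 to compound 3 (0.16 log units; that floor lies within the scatter), so how far these two groups stand apart cannot be told, though neither gives a lower number than hydrogen. From the compounds shown here alone, whether an amine or a carboxylic acid on this carbon would give a lower number than hydrogen stays open.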